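The source may hold more compounds than are shown below. What is called first, only, known or untested is meant among the compounds shown, and "the series" means these compounds.

Measured in a functional assay on U-87MG ATCC cells for inhibition, with U-87 MG (Homo sapiens) as the target, read by MTT assay, with a stated time of 48 h; on this read-out lower numbers stand for stronger inhibition and higher numbers for weaker inhibition:
- Compound 1 `Fc1ccc(/C=N/Nc2nc(-c3ccc(F)c(F)c3)cs2)cc1F`: 43900 nM
- Compound 2 `Fc1ccc(/C=N/Nc2nc(-c3ccc(Br)cc3)cs2)cc1F`: > 100000 nM

Compound 2 stands at > 100000 nM in this assay, and this is a limit of the assay, not a number. Compound 3 `Fc1ccc(/C=N/Nc2nc(-c3ccccc3)cs2)cc1F` has hydrogen in place of bromo on an aromatic carbon, para to a large group, so 4-bromophenyl becomes phenyl: hydrogen in place of bromo on an aromatic carbon.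

Among the measured compounds shown here, one measured step bears on this change: an at least 2.2-fold higher number from compound 1 to compound 2 (0.35 log units; beyond the scatter). From the compounds shown here alone, it replaces 3,4-difluorophenyl with 4-bromophenyl, and its true size remains open. For the measured compounds named here, with that step as the only guide, a modest move toward lower numbers is expected once the bromo has gone, in the direction of compound 1 at 43900 nM.

The estimated change is an at least 1.4-fold lower number from compound 2 to compound 3 (0.15 log units; that floor lies within the scatter). Compound 3 is expected at 70000 nM, with an estimated range from 30000 nM to 150000 nM.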

Compound 3, half-maximal inhibitory concentration: > 100000 nM
Compound 3 was reported as a limit; the forecaster's own chance of this, stated with the estimate: 35%; at least 1.4-fold (0.15 log units) between middle value and limit.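

Compound 3 gives > 100000 nM in this assay, and this is a limit of the assay, not a number. The step from the bromo compound to the unsubstituted phenyl compound cannot be read, so 4-bromophenyl and phenyl cannot be told apart at this position, since both compounds sit at the same limit: the limit of > 100000 nM in this assay, at which 2 of the 3 values shown sit. Phenyl in place of 3,4-difluorophenyl gives an at least 2.2-fold higher number from compound 1 to compound 3 (0.35 log units; beyond the scatter), so a higher number than that of compound 1 does not depend on the bromo being present.

From the compounds shown here alone, how far compound 2 and compound 3 truly lie from each other remains open, as does the true size of their steps from compound 1. Also open, going by these compounds, is whether a single fluoro, an amine or a carboxylic acid on this phenyl ring would bring the number back toward that of compound 1, which gives 43900 nM.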